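Thioether variation on the shared core of compound 2

This account rests on a few compounds, and the source may have more. Where it says the series, first, only, none or still open, it means among the compounds named here.

Within the data shown here, compound 2 `Cc1cc(Nc2cc(-c3ccccc3)[nH]n2)n2nc(SCC(=O)c3ccccc3)nc2n1` stands with the lower of the two numbers measured so far in a functional assay on MGC-803 cells (Homo sapiens) for inhibition, read by MTT assay, with a stated time of 72 h (on this read-out higher numbers stand for weaker inhibition and lower numbers for stronger inhibition), giving 2580 nM; compound 1 `Cc1cc(Nc2ccn(Cc3ccccc3)n2)n2nc(SCc3ccc(Br)cc3)nc2n1` gives 4720 nM in this assay, and the two values lie within the scatter of each other, so no order between them is claimed. Compound 3 `Cc1ccc(CSc2nc3nc(C)cc(Nc4cc(-c5ccccc5)[nH]n4)n3n2)cc1` keeps the core and the phenyl-bearing pyrazole of compound 2 and alters only the thioether arm: 4-methylphenyl in place of benzoyl on a saturated chain carbon bound to a sulfur. Among the measured compounds shown here, compound 1 carries a benzyl-type thioether with a different pyrazole substituent, so it offers no single-change step toward compound 3. With the same change absent among the measured pairs, the step from compound 2 to compound 3 is expected to be small, a 1.4-fold higher number from compound 2 to compound 3 (0.13 log units; within the scatter), not beyond the scatter in either direction. Compound 3 is therefore estimated at 3500 nM in this assay, within a range from 1200 nM to 10000 nM.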

Compound 3, half-maximal inhibitory concentration: 6960 nM
For compound 3 the middle estimate is 2.0-fold (0.30 log units) below the measured one; the measured number falls inside the stated range.
By their numbers in this assay, from the lowest: compounds 2, 1 and 3 (each within the scatter of the next, the first and the last beyond it).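

Among these compounds, the only single-place step so far falls on the thioether arm, and in this assay it gives a 2.7-fold higher number from compound 2 to compound 3 (0.43 log units; beyond the scatter), beyond the scatter and modest in size. The place on the saturated chain carbon bound to a sulfur is therefore not silent: 4-methylphenyl in place of benzoyl goes with weaker inhibition on the phenyl-bearing pyrazole of compound 2. No measurement in hand accounts for this step.

The change removes the carbonyl and its hydrogen-bond acceptor and also brings in a methyl group, so this one pair cannot separate the two contributions. From the compounds shown here alone, how an unsubstituted benzyl, a longer chain, or an arm ending in an amine or a carboxylic acid would read at this place remains open.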